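This account rests on a few compounds, and the source may have more. Where it says the series, first, only, none or still open, it means among the compounds named here.

Measured so far:
compound 1 `CCCCCCCCCCNc1ccn([C@H]2C[C@H](O)[C@@H](CO)O2)c(=O)n1`: 200000 nM
compound 2 `CCCCCCCCCCNc1nc(=O)n([C@H]2C[C@H](O)[C@@H](CO)O2)cc1C`: 156000 nM
compound 3 `O=c1nc(NCCCCc2ccccc2)ccn1[C@H]1C[C@H](O)[C@@H](CO)O1`: 90000 nM

These numbers come from an ADME assay on A549 cells (Homo sapiens) for cytotoxicity, read by MTT assay; on this read-out lower numbers stand for higher toxicity in this test and higher numbers for lower toxicity in this test. There, compound 1 gives 200000 nM, which puts it at the upper end of the three numbers. It shares that end with compound 2 within the scatter, while compound 3 lies lower, beyond the scatter.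

Compound 4 `CCCCCCCCCCNc1ccn([C@@H]2O[C@H](CO)[C@@H](O)[C@H]2O)c(=O)n1` has not yet been measured. It differs from compound 1 by hydroxy in place of hydrogen on a saturated ring carbon. The group 4-hydroxy-5-(hydroxymethyl)oxolan-2-yl thus becomes 3,4-dihydroxy-5-(hydroxymethyl)oxolan-2-yl.

For the measured compounds named here, no measured step makes this change, so the evidence is indirect. The two single changes elsewhere in the molecule give only a sense of scale. Methyl in place of hydrogen on an aromatic carbon gives a 1.3-fold lower number from compound 1 to compound 2 (0.11 log units; within the scatter). Phenyl in place of hexyl on the chain gives a 2.2-fold lower number from compound 1 to compound 3 (0.35 log units; beyond the scatter). Both steps are small, and neither says which way a new hydroxy should push the number. The expected result in this assay is therefore no shift beyond the scatter, shown as the estimated 1.1-fold lower number from compound 1 to compound 4 (0.05 log units; within the scatter). For compound 4 the estimated value is 180000 nM, with an expected range of 85000 nM to 380000 nM.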

Compound 4, half-maximal cytotoxic concentration: 90000 nM
Compound 4: middle estimate off by 2.0-fold (0.30 log units), on the high side, within the range that was stated.
By their numbers in this assay, from the lowest: compounds 3, 4, 2 and 1 (each within the scatter of the next, the first and the last beyond it).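

In this assay, hydroxy in place of hydrogen on this saturated ring carbon, which turns 4-hydroxy-5-(hydroxymethyl)oxolan-2-yl into 3,4-dihydroxy-5-(hydroxymethyl)oxolan-2-yl, gives a 2.2-fold lower number from compound 1 to compound 4 (0.35 log units; beyond the scatter). For the compounds shown here, the earlier steps touched only an aromatic carbon, with a 1.3-fold lower number from compound 1 to compound 2 (0.11 log units; within the scatter), and the chain, with a 2.2-fold lower number from compound 1 to compound 3 (0.35 log units; beyond the scatter), so this result is the first to show that a change on the oxygen-containing ring can also move the number beyond the scatter, here modestly and toward higher toxicity in this test. Nothing measured here explains the drop.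

The compounds shown leave open whether a different group at this ring carbon, such as fluorine, methoxy or an amine, would lower the number as hydroxy does, or whether the hydroxy with the opposite spatial orientation would behave alike. Going by these compounds alone, they also leave open whether the same hydroxy would have a similar effect on the methyl-bearing compound 2 or on compound 3 with its phenyl-ended chain, since this change is seen only on compound 1.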